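A Larger Ring on the Ether Oxygen

The source may hold more compounds than are shown below. What is called first, only, known or untested is meant among the compounds shown, and "the series" means these compounds.

Of the compounds shown here, three that share a common core have been tested in an assay on cells for binding affinity to Neuropeptide Y receptor type 1 (Homo sapiens); a higher number here means a weaker inhibitor, a lower number a stronger inhibitor. Compound 1 `CCc1sc(CCc2cc(OC)cc(NCc3cc(Cl)cc(NC(=O)OC(C)C)c3)n2)nc1C` carries a methyl on an oxygen on an aromatic ring and gives 234 nM. Compound 2 `CC/C=C\CCOc1cc(CCc2nc(C)c(CC)s2)nc(NCc2cc(Cl)cc(NC(=O)OC(C)C)c2)c1` carries a hex-3-en-1-yl chain on that oxygen and gives 4.7 nM. Compound 3 `CCc1sc(CCc2cc(OC3CCCC3)cc(NCc3cc(Cl)cc(NC(=O)OC(C)C)c3)n2)nc1C` carries a cyclopentyl there and gives 11 nM, which places it second of the three numbers, closer to compound 2 than to compound 1. Going from the methyl to the cyclopentyl gave a 21-fold lower number from compound 1 to compound 3 (1.33 log units; beyond the scatter); going from the chain to the cyclopentyl gave a 2.3-fold higher number from compound 2 to compound 3 (0.37 log units; beyond the scatter).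

Compound 4 `CCc1sc(CCc2cc(OC3CCCCC3)cc(NCc3cc(Cl)cc(NC(=O)OC(C)C)c3)n2)nc1C` is the next variation on the same oxygen: cyclohexyl in place of cyclopentyl on an oxygen on an aromatic ring. Both measured steps bear on it, since both change what sits on this oxygen. The large step to compound 3 from the methyl shows that a bigger group there can matter a great deal, while the modest step from the chain shows that not every bigger group helps. The change from cyclopentyl to cyclohexyl is small in comparison, so only a small step down in this assay, or none beyond the scatter, is expected: a 1.4-fold lower number from compound 3 to compound 4 (0.14 log units; within the scatter). Compound 4 is therefore estimated at 8 nM, with a range from 3 nM to 25 nM.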

Compound 4, half-maximal inhibitory concentration: 29 nM
For compound 4 the middle estimate is 3.6-fold (0.56 log units) below the measured one, outside the stated range (above it).
By their numbers in this assay, from the lowest: compound 2; then compound 3; then compound 4; then compound 1.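

Ring size on this oxygen matters in this assay: a six-membered ring in place of a five-membered one is a real change, not a neutral swap (a 2.6-fold higher number from compound 3 to compound 4 (0.42 log units; beyond the scatter)). Cyclohexyl still does far better than the methyl (an 8.1-fold lower number from compound 1 to compound 4 (0.91 log units; beyond the scatter)), but that gain is smaller than the one cyclopentyl gave, and cyclohexyl falls well short of the hex-3-en-1-yl chain (a 6.2-fold higher number from compound 2 to compound 4 (0.79 log units; beyond the scatter)). The number therefore does not simply fall as the group on this oxygen grows: it drops from methyl to cyclopentyl and then rises again at cyclohexyl, so among these rings the five-membered one gives the lower number, and the open chain gives the lowest of all four.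

No evidence at hand explains why the six-membered ring gives a higher number than the five-membered one.

Also open, from the compounds shown here alone, is how other groups on this oxygen would fare, such as a cyclobutyl ring, a tetrahydropyranyl ring that carries an oxygen of its own, or a saturated hexyl chain that would show whether the double bond of the hex-3-en-1-yl chain matters.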